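Swapping an Amide for a Pyridylmethyl Group on the Ring Amine

The source may report more compounds than this note shows. Statements on the series, on what has been measured and on what is new or still open speak of the compounds shown alone.

The measured compounds:
- compound 1 `CCCCNc1nc(N)nc2c1CCNC2`, 0.6 uM
- compound 2 `CCCCNc1nc(N)nc2c1CN(C(=O)c1ccccc1)CC2`, 1.4 uM
- compound 3 `CCCCNc1nc(N)nc2c1CN(Cc1cccc3ccccc13)CC2`, 0.43 uM

All three were tested in an assay on HEK293 cells for agonist activity at Toll-like receptor 8 (Homo sapiens), read by a luciferase reporter, with a stated time of 6 h; a higher number here means that more compound is needed for the effect, a lower number that less compound is needed. Compound 2 stands at the high end of the three: compound 1 gives a lower number, and compound 3 a lower number still, and both of those gaps are beyond the usual scatter of this assay. Compound 2 is therefore the one of the three that needs the most material to reach the effect.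

The step under consideration leads to compound 4 `CCCCNc1nc(N)nc2c1CN(Cc1ccccn1)CC2`. The change on the amine nitrogen in the ring is (pyridin-2-yl)methyl in place of benzoyl on an amine nitrogen in a ring. The substituent that enters is attached through a methylene, as in compound 3, rather than through a carbonyl, as in compound 2.

Going by the values given here, no direct step between measured compounds matches this change. Still, both compound 1 and compound 3 give lower numbers than compound 2 in this assay, and compound 4 resembles compound 3 in how its group is attached. The expectation is that the step of a 2.8-fold lower number from compound 2 to compound 4 (0.45 log units; beyond the scatter) will be a decrease beyond the scatter. The estimated value for compound 4 is 0.5 uM, with a range from 0.2 uM to 1.4 uM.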

Compound 4, minimum effective concentration: 0.07 uM
Compound 4: the middle estimate sits 7.1-fold (0.85 log units) above what was measured; the measured number lies below the stated range.
By their numbers in this assay, from the lowest: compound 4; then compounds 3 and 1 (each within the scatter of the next); then compound 2.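

In this assay, going by these compounds alone, the change on the amine nitrogen in the ring gives a 20-fold lower number from compound 2 to compound 4 (1.30 log units; beyond the scatter), the first single change at this position that can be read, and it is a large one. Within the data shown here, a methylene attachment alone does not set the number, since compound 3 has its group attached through a methylene too and gives 0.43 uM, while compound 4 gives 0.07 uM, the lowest of the four numbers, so the ring that enters also counts at this nitrogen, and the earlier compounds could not show this. Nothing shown here explains the size of this step.

On these data alone, the step replaces a carbonyl attachment and a carbon-only aromatic ring together, so the share of each remains open: a benzyl group on this nitrogen would show what the methylene does without the ring nitrogen, and a pyridine-2-carbonyl group would show what the ring nitrogen does with the carbonyl kept. As far as these compounds go, whether the place of the nitrogen within the ring matters is also open, and a (pyridin-3-yl)methyl or (pyridin-4-yl)methyl group would address that.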